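A few compounds are considered here, and "the series" means these few. Any claim that something is new, unique, unknown or untested is made for them only; others in the source may bear on it.

Of the compounds shown here, three sharing one core have been tested in a functional assay on MCF7 cells (Homo sapiens) for cytotoxicity, read by MTT assay, with a stated time of 48 h; on this read-out lower numbers stand for stronger inhibition and higher numbers for weaker inhibition. Compound 1, `COc1cc(C(=O)C2Sc3nnc(-c4cc(OC)c(OC)c(OC)c4)n3NC2c2ccco2)cc(OC)c1OC`, carries a 3,4,5-trimethoxyphenyl group on its carbonyl carbon. In this assay compound 1 reaches only the limit of > 100000 nM. Compound 2, `COc1cc(-c2nnc3n2NC(c2ccco2)C(C(=O)c2cccs2)S3)cc(OC)c1OC`, has a thiophen-2-yl group in that position, and in this assay compound 2 likewise gives the limit of > 100000 nM. Compound 3, `COc1ccc(C(=O)C2Sc3nnc(-c4cc(OC)c(OC)c(OC)c4)n3NC2c2ccco2)cc1`, bears a 4-methoxyphenyl group on the carbonyl carbon. In this assay compound 3 too stands at the limit of > 100000 nM, so no number is known for it, and compound 3 sits level with the other two as far as the limits allow one to say.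

The measured steps say nothing readable: a step that the two limits leave unreadable from compound 1 to compound 2, a step that the two limits leave unreadable from compound 1 to compound 3 and a step that the two limits leave unreadable from compound 2 to compound 3 all remain hidden because of the limit of > 100000 nM in this assay, at which 3 of the 3 values shown sit.

Compound 4, `COc1cc(-c2nnc3n2NC(c2ccco2)C(C(=O)c2ccc(-c4ccccc4)cc2)S3)cc(OC)c1OC`, differs from compound 3 by phenyl in place of methoxy on an aromatic carbon. Among the measured compounds shown here, none of the measured steps concerns a change at this position, and none gave a readable size, so there is no basis for expecting a shift beyond the scatter. The step from compound 3 to compound 4 is therefore estimated as a number no higher from compound 3 to compound 4 (the limit leaves the size open), with the chance high that only a limit is reported again. Compound 4 is expected to give about 100000 nM, within a range from 20000 nM to 400000 nM.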

Compound 4, half-maximal inhibitory concentration: > 100000 nM
Compound 4: a limit, no number (the forecaster's own chance of this, stated with the estimate: 80%); the middle value lies on the limit itself.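

No step from compound 1, compound 2 or compound 3 to compound 4 can be read, because compound 4, like the other three, gives only a limit: the limit of > 100000 nM in this assay, at which 4 of the 4 values shown sit.

The compounds shown leave open whether any group on the carbonyl carbon of the shared core would give a readable number in this assay.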